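Benzimidazole-phenol series: chloro to nitro on the fused ring

The source may hold more compounds than are shown below. What is called first, only, known or untested is meant among the compounds shown, and "the series" means these compounds.

Measured so far:
compound 1 `COc1cc(-c2nc3cc(Cl)ccc3[nH]2)cc(I)c1O` gives 1610 nM in an assay for inhibition of Alpha amylase (Homo sapiens), with a stated time of 10 min; a lower number here means a stronger inhibitor, a higher number a weaker inhibitor
compound 2 `COc1cc(-c2nc3cc(Cl)ccc3[nH]2)cc(OC)c1O` gives 2520 nM in this assay

For the measured compounds named here, compound 1 has the lowest of the two numbers so far in this assay; its nearest neighbour is compound 2, and the step of a 1.6-fold higher number from compound 1 to compound 2 (0.19 log units; within the scatter) lies within the scatter, so the two compounds cannot be ordered.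

Compound 3 `COc1cc(-c2nc3cc([N+](=O)[O-])ccc3[nH]2)cc(I)c1O` is not yet measured in this assay. Its difference from compound 1 is nitro in place of chloro on an aromatic carbon — nitro in place of chloro on an aromatic carbon. Going by the values given here, no measured step touches this part of the shared core: the only step known, from compound 1 to compound 2, changes the other ring. There is therefore nothing to carry over, and the expectation is for no step beyond the scatter, a 1.0-fold lower number from compound 1 to compound 3 (0.00 log units; within the scatter). Compound 3 is estimated at 1600 nM, in a range from 500 nM to 5000 nM, with the range kept wide since no comparable change has been measured.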

Compound 3, half-maximal inhibitory concentration: 1720 nM
Estimate against measurement, compound 3: 1.1-fold (0.03 log units) below, within the range that was stated.
By their numbers in this assay, from the lowest: compounds 1, 3 and 2 (each within the scatter of the next).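

The position on the fused ring, untouched by the earlier step, now has a measured change: in this assay, nitro in place of chloro gives a 1.1-fold higher number from compound 1 to compound 3 (0.03 log units; within the scatter). The entering nitro has more heavy atoms and more hydrogen-bond acceptors than the leaving chloro, yet the two compounds cannot be ordered, so this single exchange shows no sensitivity to the change at this position beyond the scatter. No further data bear on this result.

For the compounds shown here, it remains open whether an amine or a carboxylic acid at this position would also stay within the scatter, since chloro and nitro are the only two groups compared here. Also open, going by these compounds, is whether the step from chloro to nitro would keep its size with methoxy in place of iodo on the other ring.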